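Piperidine nitrogen substituent and chromatographic lipophilicity

A few compounds are considered here, and "the series" means these few. Any claim that something is new, unique, unknown or untested is made for them only; others in the source may bear on it.

Measured so far:
compound 1 `O=C(C1CCCCC1)N1CCC(C(=O)N2N=CCC2c2ccccc2)CC1` 5.4
compound 2 `O=C(C1CCN(c2ccccc2)CC1)N1N=CCC1c1ccccc1` 6.3

In a physicochemical assay for lipophilicity, read by HPLC, measured as chromatographic lipophilicity, at pH 7.4 (a higher number here means a more lipophilic compound, a lower number a more polar compound), compound 2 stands highest of the two numbers, with compound 1 lower by a number 0.90 log units higher from compound 1 to compound 2 (beyond the scatter). Compound 3 `O=C(c1cocn1)N1CCC(C(=O)N2N=CCC2c2ccccc2)CC1` differs from compound 2 by (1,3-oxazol-4-yl)carbonyl in place of phenyl on an amine nitrogen in a ring. Among the measured compounds shown here, only the step from compound 1 to compound 2 bears on this, as a carbonyl-linked group against phenyl on the same ring nitrogen; an aromatic ring with two heteroatoms entering carries more acceptors than either. A clearly downward step is therefore expected, a number 2.40 log units lower from compound 2 to compound 3 (beyond the scatter), with compound 3 estimated at 3.9, range 3.2 to 4.6.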

Compound 3, distribution coefficient: 2.9
Compound 3: middle estimate off by 1.00 log units, on the high side, and the stated range ends above it.
By their numbers in this assay, from the lowest: compound 3; then compound 1; then compound 2.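

On the amine nitrogen in the ring, the change to (1,3-oxazol-4-yl)carbonyl from phenyl moves this assay by a large step (a number 3.40 log units lower from compound 2 to compound 3 (beyond the scatter)), larger than any step seen earlier in the series. With the carbonyl kept, 1,3-oxazol-4-yl in place of cyclohexyl on a carbonyl carbon also gives a large step (a number 2.50 log units lower from compound 1 to compound 3 (beyond the scatter)), so the carbonyl link alone does not account for the low number of compound 3. No measurement at hand bears on the cause. Open, going by these compounds, is where a pyridine ring or a simple methyl on that carbonyl carbon would fall in this assay relative to compound 1 and compound 3.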